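Furan in place of dimethoxyphenyl: an untested step

This account rests on a few compounds, and the source may have more. Where it says the series, first, only, none or still open, it means among the compounds named here.

compound 1 `COc1ccc(-c2nc(SC)n(C)c(=O)c2C#N)cc1`: 48 ug/mL
compound 2 `CCOC(=O)c1cnn(-c2nc(-c3cccc(OC)c3OC)c(C#N)c(=O)n2C)c1N`: 67 ug/mL

In a functional assay, with a stated time of 10 min (on this read-out lower numbers stand for stronger inhibition and higher numbers for weaker inhibition), compound 1 gives 48 ug/mL and compound 2 gives 67 ug/mL; the two numbers lie within the usual scatter of each other, so neither compound can be called the stronger one. Compound 3 `CCOC(=O)c1cnn(-c2nc(-c3ccco3)c(C#N)c(=O)n2C)c1N` has not yet been measured. It differs from compound 2 in one place: furan-2-yl in place of 2,3-dimethoxyphenyl on an aromatic carbon. Within the data shown here, no measured pair shows what such a swap does here, so no step beyond the scatter is expected. Compound 3 is estimated at 80 ug/mL, within a range from 30 ug/mL to 200 ug/mL. This expected step amounts to a 1.2-fold higher number from compound 2 to compound 3 (0.08 log units; within the scatter).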

Compound 3, half-maximal inhibitory concentration: 104 ug/mL
Beside the measured number, compound 3's estimate is 1.3-fold (0.11 log units) below it; the measured number falls inside the stated range.
By their numbers in this assay, from the lowest: compounds 1, 2 and 3 (each within the scatter of the next, the first and the last beyond it).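

In this assay, furan-2-yl in place of 2,3-dimethoxyphenyl gives a 1.6-fold higher number from compound 2 to compound 3 (0.19 log units; within the scatter). This first measured pair at this position shows that the read-out does not separate the two groups, even though furan-2-yl has fewer heavy atoms than 2,3-dimethoxyphenyl. Nothing available explains this result. Still open, on these data alone, is whether either methoxy group matters on its own, as a plain phenyl ring would test. Also open, as far as these compounds go, is how an amine or a longer alkyl chain would read out on this aromatic carbon.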